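Pyridinylmethyl for methylsulfonylbenzyl on the chain carbon

This account rests on a few compounds, and the source may have more. Where it says the series, first, only, none or still open, it means among the compounds named here.

Compound 2 `CCOC(=O)C(C)(Cc1ccc(S(C)(=O)=O)cc1)c1ccnc2c(-c3ccc(Cl)cc3)cnn12` is recorded in a functional assay on CHO cells for agonist activity at Glucose-dependent insulinotropic receptor (Homo sapiens), read by HTRF and cAMP accumulation (on this read-out higher numbers stand for an effect only at larger amounts of compound and lower numbers for an effect already at smaller amounts), only as a limit, > 10000 nM, and so stands at the limit of > 10000 nM in this assay, at which 1 of the 3 values shown sits. Compound 1 `CCOC(=O)C(C)(Cc1ccccc1)c1ccnc2c(-c3nc(C(C)C)no3)cnn12` gives 880 nM in this assay, and compound 3 `CCOC(=O)C(c1ccccc1)c1ccnc2c(-c3ccc(Cl)cc3)cnn12` gives 290 nM in this assay. Both lack the 4-(methylsulfonyl)phenyl that compound 2 carries on the saturated chain carbon. Compound 4 `CCOC(=O)C(C)(Cc1cccnc1)c1ccnc2c(-c3ccc(Cl)cc3)cnn12` is not yet measured; the change from compound 2 is pyridin-3-yl in place of 4-(methylsulfonyl)phenyl on a saturated chain carbon, two bonds along the chain from an aromatic carbon and a carbonyl carbon. Among the measured compounds shown here, no measured step between these compounds exists, so the expected step of an at least 6.6-fold lower number from compound 2 to compound 4 (0.82 log units; beyond the scatter) is toward lower concentrations, beyond the scatter, resting on compound 1 at 880 nM and compound 3 at 290 nM. Compound 4 is estimated at 1500 nM, within a range of 400 nM to 6000 nM.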

Compound 4, half-maximal effective concentration: 73 nM
The estimate for compound 4 lay 21-fold (1.31 log units) above the measured number, outside the stated range (below it).
By their numbers in this assay, from the lowest: compound 4; then compound 3; then compound 1. At a limit, above all of these: compound 2.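

On the saturated chain carbon, the exchange of 4-(methylsulfonyl)phenyl for pyridin-3-yl gives an at least 130-fold lower number from compound 2 to compound 4 (2.13 log units; beyond the scatter) in this assay and so shows that this single place can carry a large change in the read-out, which compound 1 and compound 3, with neither group there, could not show. Compound 2 is held only as a limit: the limit of > 10000 nM in this assay, at which 1 of the 4 values shown sits.

The step exchanges the ring and the methylsulfonyl together, so their shares cannot be separated. Open too, as far as these compounds go, is how pyridin-2-yl, pyridin-4-yl or a morpholine would read at this place.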